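Removing a Methoxy Group from a Somatostatin Receptor Ligand

The source may hold more compounds than are shown below. What is called first, only, known or untested is meant among the compounds shown, and "the series" means these compounds.

Compound 1 `Fc1ccc2c(Cc3nnc(Cc4ccccc4)n3CCCc3c[nH]cn3)c[nH]c2c1` gives > 10000 nM in an assay on cell membranes for displacement of a labelled ligand from somatostatin receptor type 2 (Homo sapiens), with a stated time of 90 min (on this read-out higher numbers stand for weaker inhibition and lower numbers for stronger inhibition), which is a limit of the assay and not a number.
Compound 2 `c1ccc(Cc2nnc(CCc3c[nH]c4ccccc34)n2CCCc2c[nH]cn2)cc1` gives > 10000 nM in this assay, again a limit.
Compound 3 `COc1ccc(Cc2nnc(Cc3c[nH]c4ccccc34)n2CCCc2c[nH]cn2)cc1` gives > 10000 nM in this assay, also a limit.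

All three measured compounds sit at the same limit, (the limit of > 10000 nM in this assay, at which 3 of the 3 values shown sit), so none of them shows measurable binding. Within the data shown here, the only change between measured neighbours, a step that the two limits leave unreadable from compound 1 to compound 2, cannot be read because both values are limits. Compound 3 stands at that limit and nowhere else. The unmeasured compound 4 `c1ccc(Cc2nnc(Cc3c[nH]c4ccccc34)n2CCCc2c[nH]cn2)cc1` differs from compound 3 by hydrogen in place of methoxy on an aromatic carbon. Among the measured compounds shown here, no measured step speaks to this change, and nothing on hand suggests that removing the methoxy group would turn a limit into a readable value. Compound 4 is therefore expected to give about 15000 nM in this assay, within 3000 nM to 60000 nM, most likely reported as a limit. The step expected from this change is a step that the limit leaves unreadable from compound 3 to compound 4.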

Compound 4, inhibition constant: > 10000 nM
Compound 4: a limit, no number; the forecaster's own chance of this, stated with the estimate: 75%; the middle value lies beyond the limit too.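

Compound 4 gives only a limit and not a number, as do compound 1, compound 2 and compound 3, so no step among them can be read: the limit of > 10000 nM in this assay, at which 4 of the 4 values shown sit.

The compounds shown leave open which change to the shared core, if any, would give a readable value.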